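The compounds below may be only part of what the source reports. "The series", "measured", "known", "first", "only" and "open" are said of these compounds alone.

Working notes on the series. Three compounds share one core and differ only in the group on an amine nitrogen. Compound 1 `CCOc1ccccc1NC1=CC(=O)c2c(nc3n2[C@H]2OC[C@@H](O)[C@H]2OC3)C1=O` gives 8300 nM in a functional assay on HeLa cells (Homo sapiens) for inhibition, read by sulforhodamine B assay; a lower number here means a stronger inhibitor, a higher number a weaker inhibitor. Compound 2 `O=C1C(Nc2ccc(C(F)(F)F)cc2)=CC(=O)c2c1nc1n2[C@H]2OC[C@@H](O)[C@H]2OC1` gives 8920 nM in this assay. Compound 3 `O=C1C(NCc2ccccc2)=CC(=O)c2c1nc1n2[C@H]2OC[C@@H](O)[C@H]2OC1` gives 11000 nM in this assay and so stands with the highest number of the three, though its steps to both neighbours are within the scatter: a 1.3-fold higher number from compound 1 to compound 3 (0.12 log units; within the scatter) and a 1.2-fold higher number from compound 2 to compound 3 (0.09 log units; within the scatter). The remaining step, a 1.1-fold higher number from compound 1 to compound 2 (0.03 log units; within the scatter), is likewise within the scatter, so swapping the aryl groups on this nitrogen has not moved the read-out so far.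

Compound 4 `O=C1C(Nc2cccc(F)c2)=CC(=O)c2c1nc1n2[C@H]2OC[C@@H](O)[C@H]2OC1` is not yet measured. It differs from compound 3 as follows: 3-fluorophenyl in place of benzyl on an amine nitrogen. Within the data shown here, the steps that bear on it are those where benzyl was exchanged for an aryl group on this nitrogen, a 1.2-fold higher number from compound 2 to compound 3 (0.09 log units; within the scatter) and a 1.3-fold higher number from compound 1 to compound 3 (0.12 log units; within the scatter), both small. On that basis no step beyond the scatter is expected from compound 3 to compound 4 in this assay, and the estimate for that step is a 1.2-fold lower number from compound 3 to compound 4 (0.06 log units; within the scatter). Compound 4 is therefore expected to give about 9500 nM in this assay, with a range from 4500 nM to 20000 nM.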

Compound 4, half-maximal inhibitory concentration: > 8000 nM
Compound 4 was reported as a limit; the forecaster's own chance of this, stated with the estimate: 5%; the middle value is on the limit's open side.
By their numbers in this assay, from the lowest: compounds 1, 2 and 3 (each within the scatter of the next).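

In this assay compound 4 gives > 8000 nM, which is a limit and not a number. Among these compounds, no step from compound 1, compound 2 or compound 3 to compound 4 can therefore be read. The compounds shown leave open whether compound 4 sits within the scatter of the other three or beyond it.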